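The source may report more compounds than this note shows. Statements on the series, on what has been measured and on what is new or still open speak of the compounds shown alone.

Compound 1 `COc1cc(N2CCN(C)CC2)ccc1Nc1nccc(-c2cn(C)c3c(C)nccc23)n1` gives 6 uL/min in an ADME assay on cells (Hepatocyte, Rattus norvegicus, strain Wistar Han) for metabolic stability; a higher number here means faster removal of the compound, a lower number slower removal. Compound 2 `O=C(NC1CCCC1)c1ccc(-c2nccc(-c3c[nH]c4cnccc34)n2)cc1` gives 32 uL/min in this assay. Compound 3 `CN1CCN(c2ccc(Nc3cc(-c4c[nH]c5cnccc45)ncn3)cc2)CC1` gives 13 uL/min in this assay.

Among the three numbers, compound 3 stands second highest: its number is beyond the scatter above that of compound 1 and beyond the scatter below that of compound 2.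

Compound 4 `CN1CCN(c2ccc(Nc3cc(-c4c[nH]c5ccccc45)ncn3)cc2)CC1` differs from compound 3 in one place: a group of 9 heavy atoms (8 carbon, 1 nitrogen; one five-membered aromatic ring with 1 hetero atom, one six-membered aromatic ring of carbon only) in place of a group of 9 heavy atoms (7 carbon, 2 nitrogen; one five-membered aromatic ring with 1 hetero atom, one six-membered aromatic ring with 1 hetero atom), on an aromatic carbon

Going by the values given here, no measured pair here carries this change, so its effect on the number cannot be read from the data. The estimated step from compound 3 to compound 4 is a 1.5-fold higher number from compound 3 to compound 4 (0.19 log units; within the scatter), an expected modest rise that may still lie within the scatter. Compound 4 is expected to give 20 uL/min in this assay, with a range from 8 uL/min to 50 uL/min.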

Compound 4, intrinsic clearance in a liver preparation (reported as CLH), per the amount of preparation that the assay uses: 49 uL/min
Compound 4: the middle estimate sits 2.5-fold (0.39 log units) below what was measured, and the stated range covers the measured number.
By their numbers in this assay, from the lowest: compound 1; then compound 3; then compounds 2 and 4 (each within the scatter of the next).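

Exchanging the group on this aromatic carbon for 1H-indol-3-yl gives a 3.8-fold higher number from compound 3 to compound 4 (0.58 log units; beyond the scatter) in this assay. Going by these compounds alone, compounds 3 and 4 form the first pair here that differs in one place, and they show that the number at this position responds to replacing the ring with one hetero atom by a ring of carbon only, with the heavy-atom count unchanged. Nothing available here bears on why the number rises.

On these data alone, whether the same exchange gives a similar step on the cores of compound 1 or compound 2 stays open. So does whether a fluorine or an amine on the carbon-only ring would bring the number back toward that of compound 3.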